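This account rests on a few compounds, and the source may have more. Where it says the series, first, only, none or still open, it means among the compounds named here.

Compound 1 `CCCc1nc(-c2ccccc2)c(CNCCCN2CCN(c3ccc(OC)cc3)CC2)o1` stands lowest of the two measured compounds: in an assay on HEK293 cells for inhibition of Voltage-dependent T-type calcium channel subunit alpha-1G (Homo sapiens), read by fluorescence, tested at 10 uM (on this read-out lower numbers stand for less inhibition and higher numbers for more inhibition at the one concentration tested (going by the name of the read-out)), compound 1 gives 42.1%, while compound 2 `CCCc1nc(-c2ccccc2)c(CNCCN2CCN(C(c3ccccc3)c3ccccc3)CC2)o1` gives 71.9%, a gap beyond the usual scatter. Compound 3 `CCCc1nc(-c2ccccc2)c(CNCCCN2CCN(c3ccccc3OC)CC2)o1` differs from compound 1 in one place, (2-methoxyphenyl in place of 4-methoxyphenyl on an amine nitrogen in a ring). Among the compounds with values here, no measured pair shows a change of this kind, so its size cannot be read from the data; a step no larger than the scatter, in either direction, is expected. The expected step of a number 2.9 percentage points higher from compound 1 to compound 3 (within the scatter) is therefore small. Compound 3 is estimated to give 45% in this assay, with a range from 25% to 65%.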

Compound 3, a percentage reported as inhibition, at one concentration (the size of the read-out at that concentration, not a potency): 41%
Estimate against measurement, compound 3: 4 percentage points above; low and high end bracket the measured number.
By their numbers in this assay, from the lowest: compounds 3 and 1 (each within the scatter of the next); then compound 2.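

In this assay, 2-methoxyphenyl in place of 4-methoxyphenyl on the amine nitrogen in the ring gives a number 1.1 percentage points lower from compound 1 to compound 3 (within the scatter) and so leaves the read-out within the usual scatter. Within the data shown here, this is the first pair that differs in one place, and at this position the two methoxyphenyl groups cannot be told apart. No available evidence bears on this result.

Still open, on these data alone, is whether 3-methoxyphenyl, unsubstituted phenyl or 4-chlorophenyl in the same place would give a step beyond the scatter.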